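This account rests on a few compounds, and the source may have more. Where it says the series, first, only, none or still open, it means among the compounds named here.

The compounds here share one core and differ in the groups hung on it. Compound 1 `O=C(N[C@H]1CCC[C@H](CO)C1)C1CCN(c2nc3cc(Cl)c(-c4cccc(Cl)c4)cc3o2)CC1` is measured in an ADME assay on microsomes from liver (Homo sapiens) for metabolic stability (a higher number here means faster removal of the compound, a lower number slower removal), where compound 1 gives 55.8 mL/min/kg, the highest of the two numbers shown. Compound 2 `O=C(N[C@H]1CCC[C@H](CO)C1)C1CCN(c2nc3cc(C(F)(F)F)ccc3o2)CC1` gives 22.2 mL/min/kg in this assay. Compound 3 `N#Cc1ccc2oc(N3CCC(C(=O)N[C@H]4CCC[C@H](CO)C4)CC3)nc2c1` reaches only a limit of the assay, < 8 mL/min/kg, and no number is reported for it (the limit of < 8 mL/min/kg in this assay, at which 1 of the 3 values shown sits). Among the measured compounds shown here, the one step measured between neighbours, an at least 2.7-fold lower number from compound 2 to compound 3 (0.44 log units; beyond the scatter), lowers the number.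

The compound not yet measured is compound 4 `O=C(N[C@H]1CCC[C@H](CO)C1)C1CCN(c2nc3cc(Cl)c(-c4ccc(OC(F)(F)F)cc4)cc3o2)CC1`. It differs from compound 1 in one place: 4-(trifluoromethoxy)phenyl in place of 3-chlorophenyl on an aromatic carbon. For the measured compounds named here, no measured pair shows this kind of exchange of one aryl group for another, so the step from compound 2 to compound 3 does not bear directly on it. In the absence of a matching precedent, the expectation for compound 4 is a number close to that of compound 1, with a 1.1-fold lower number from compound 1 to compound 4 (0.05 log units; within the scatter) expected to fall within the scatter. The estimate for compound 4 in this assay is 50 mL/min/kg, between 25 mL/min/kg and 100 mL/min/kg.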

Compound 4, clearance: 50.8 mL/min/kg
For compound 4 the middle estimate is 1.0-fold (0.01 log units) below the measured one, and the stated range covers the measured number.
By their numbers in this assay, from the lowest: compound 2; then compounds 4 and 1 (each within the scatter of the next). At a limit, below all of these: compound 3.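

Exchanging 3-chlorophenyl for 4-(trifluoromethoxy)phenyl on this aromatic carbon, ortho to a chloro group, gives a 1.1-fold lower number from compound 1 to compound 4 (0.04 log units; within the scatter) in this assay. Among the compounds shown here, this is the first measured exchange of one aryl group for another here, and it shows that a larger group of 11 heavy atoms in place of 7, with a different substituent at a different place on the phenyl ring, leaves the two compounds indistinguishable in this read-out. Nothing measured here gives a reason for this result.

Still open, on these data alone, is whether an amine or a carboxylic acid on that phenyl ring would give a number outside the scatter of compound 1. Also open, as far as these compounds go, is how a plain hydrogen in place of the whole aryl group would compare with compound 1.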